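This account rests on a few compounds, and the source may have more. Where it says the series, first, only, none or still open, it means among the compounds named here.

Compound 1 `CC(C)(C)OC(=O)NCCC[C@@H]1N=C2C[C@@H]3C[C@@H](C3(C)C)[C@]2(C)OC1=O`: in a functional assay on EL4 cells (Mus musculus) for antiproliferative activity, read by sulforhodamine B assay, with a stated time of 48 h (a lower number here means a stronger inhibitor, a higher number a weaker inhibitor), compound 1 gives 4100 nM.
Compound 2 `CC1(C)[C@@H]2CC3=N[C@@H](CCC(=O)O)C(=O)O[C@@]3(C)[C@H]1C2`: in this assay compound 2 gives 36000 nM.

Of these two numbers, compound 1 has the lower one, and its gap to compound 2 lies beyond the usual scatter, so compound 1 is the stronger inhibitor of the pair. Compound 3 `CC(C)(C)OC(=O)NCCCC[C@@H]1N=C2C[C@@H]3C[C@@H](C3(C)C)[C@]2(C)OC1=O` differs from compound 1 in one place: ((tert-butoxycarbonyl)amino)methyl in place of (tert-butoxycarbonyl)amino on a saturated chain carbon, three bonds along the chain from a saturated ring carbon. For the measured compounds named here, with no measured pair of this kind to lean on, only a small step is expected, none beyond the scatter. The expected step is a 1.2-fold lower number from compound 1 to compound 3 (0.07 log units; within the scatter). Compound 3 is therefore estimated to give 3500 nM, in the range 1200 nM to 10000 nM.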

Compound 3, half-maximal inhibitory concentration: 15000 nM
Compound 3: the middle estimate sits 4.3-fold (0.63 log units) below what was measured; the measured number lies above the stated range.
By their numbers in this assay, from the lowest: compound 1; then compound 3; then compound 2.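

Lengthening the chain by a single carbon, with ((tert-butoxycarbonyl)amino)methyl in place of (tert-butoxycarbonyl)amino, gives a 3.7-fold higher number from compound 1 to compound 3 (0.56 log units; beyond the scatter) in this assay. Chain length at this position therefore matters: one added carbon weakens the compound beyond the usual scatter, though the group at the chain end stays the same. Nothing measured here gives a reason for this step.

The compounds shown leave open whether a still longer chain would weaken inhibition further. They also leave open how a free amine at the chain end would compare in this assay.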